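This account rests on a few compounds, and the source may have more. Where it says the series, first, only, none or still open, it means among the compounds named here.

Compound 1 `N#CCN(Cc1ccc(Cl)cc1)Cc1ccc([N+](=O)[O-])s1` and compound 2 `CC(C)(C)OC(=O)N1CCC(CN(Cc2ccc(Cl)cc2)Cc2ccc([N+](=O)[O-])s2)C1` share one core, a nitrothiophene and a chlorobenzyl group joined through a central nitrogen, and differ only in the third arm on that nitrogen. In a functional assay on HEK293 cells for agonist activity at nuclear receptor subfamily 1 group D member 1 (Homo sapiens), read by a luciferase reporter, with a stated time of 24 h (on this read-out lower numbers stand for an effect already at smaller amounts and higher numbers for an effect only at larger amounts of compound), compound 1 gives 2500 nM. In the same test compound 2 gives 1800 nM. Of the two numbers, that of compound 2 is the smaller, yet the gap to compound 1 is within the usual scatter, so the two cannot be told apart. Compound 3 `O=C(Nc1ccccc1)N1CCC(CN(Cc2ccc(Cl)cc2)Cc2ccc([N+](=O)[O-])s2)C1` carries one change on the arm of compound 2: anilino in place of tert-butoxy on a carbonyl carbon. No measured pair shows what such a change does here, so the step is estimated from the two numbers alone and is expected to be small, a 1.4-fold lower number from compound 2 to compound 3 (0.14 log units; within the scatter), with little reason to expect anything beyond the scatter. For compound 3 the expected value in this assay is 1300 nM, between 350 nM and 5000 nM.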

Compound 3, half-maximal effective concentration: 620 nM
For compound 3 the middle estimate is 2.1-fold (0.32 log units) above the measured one; the measured number falls inside the stated range.
By their numbers in this assay, from the lowest: compound 3; then compounds 2 and 1 (each within the scatter of the next).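

Anilino in place of tert-butoxy on a carbonyl carbon gives a 2.9-fold lower number from compound 2 to compound 3 (0.46 log units; beyond the scatter) in this assay and this modest step lies beyond the scatter. Among the compounds shown here, compound 1 and compound 2 could not be told apart, so this is the first clear difference in the set, and it shows that the outer end of this arm can shift the number. The change swaps a group without a ring for one with a six-membered aromatic ring and a hydrogen-bond donor, and no outside data explain the step.

The compounds shown leave open whether the ring or the hydrogen-bond donor of anilino carries the step. Also open, from the compounds shown here alone, is how a benzyloxy group, with a ring but no such donor, or a methylamino group, with the donor but no ring, would compare on the same carbonyl carbon.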